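Trimethoxyphenyl in Place of Pyridinyl at the Chain End

The compounds below may be only part of what the source reports. "The series", "measured", "known", "first", "only" and "open" are said of these compounds alone.

Compound 1 `CCn1nc(C)cc1C(=O)Nc1nc2cc(C(N)=O)cc(OC)c2n1CCCNC(=O)OCc1ccccc1` gives > 100000 nM in an assay for activation of interferon regulatory factor 3 (Homo sapiens), read by a luciferase reporter, with a stated time of 20 h; on this read-out lower numbers stand for an effect already at smaller amounts and higher numbers for an effect only at larger amounts of compound; this is a limit of the assay, not a number.
Compound 2 `CCn1nc(C)cc1C(=O)Nc1nc2cc(C(N)=O)cc(OC)c2n1CCCNC(=O)CCc1cccnc1` gives > 100000 nM in this assay; this too is a limit of the assay.

For the measured compounds named here, compound 2 therefore stands at the limit, and so does the only other measured compound, as the limit of > 100000 nM in this assay, at which 2 of the 2 values shown sit, records. Going by the values given here, the single step between measured compounds, a step that the two limits leave unreadable from compound 1 to compound 2, cannot be read, since both ends are limits. The change now considered is 3,4,5-trimethoxyphenyl in place of pyridin-3-yl on a saturated chain carbon, two bonds along the chain from a carbonyl carbon, giving compound 3 `CCn1nc(C)cc1C(=O)Nc1nc2cc(C(N)=O)cc(OC)c2n1CCCNC(=O)CCc1cc(OC)c(OC)c(OC)c1`. Among the compounds with values here, no measured step shows what this exchange does, and the one step that exists, from compound 1 to compound 2, gives no size. Compound 3 is therefore expected to stay where compound 2 is, with an expected step of a number no higher from compound 2 to compound 3 (the limit leaves the size open) in this assay. The estimate for compound 3 is 100000 nM, expected to lie between 30000 nM and 300000 nM, with a high chance that only a limit is reported again.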

Compound 3, half-maximal effective concentration: > 100000 nM
Compound 3: no number, only a limit (the forecaster's own chance of this, stated with the estimate: 85%); the middle value sits exactly at the limit.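

In this assay compound 3 gives > 100000 nM and this is a limit of the assay, so no new step can be read between compound 2 and compound 3. The compounds shown leave open whether any change at this chain end yields a measurable number, as all sit at one limit: the limit of > 100000 nM in this assay, at which 3 of the 3 values shown sit.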